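A few compounds are considered here, and "the series" means these few. Any claim that something is new, unique, unknown or untested is made for them only; others in the source may bear on it.

Of the compounds shown here, three sharing one core have been measured in a functional assay on KB cells (Homo sapiens) for cytotoxicity; on this read-out higher numbers stand for an effect only at larger amounts of compound and lower numbers for an effect already at smaller amounts. Compound 1 `COC1=C(C)C(=O)/C(=C(O)/C=C/c2ccc(OC)cc2)C(=O)C1(C)C` gives 2.9 ug/mL, compound 2 `COC1=C(C)C(=O)/C(=C(O)/C=C/c2ccccc2OC)C(=O)C1(C)C` gives 2.8 ug/mL, and compound 3 `COC1=C(C)C(=O)/C(=C(O)/C=C/c2ccc(F)cc2)C(=O)C1(C)C` gives 2.7 ug/mL. These numbers lie within the usual scatter of one another, so compound 2 cannot be told apart from either of the other two.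

Compound 4 `COC1=C(C)C(=O)/C(=C(O)/C=C/c2ccccc2C)C(=O)C1(C)C` has not been measured yet and differs from compound 2 at a single place: methyl in place of methoxy on an aromatic carbon. This puts methyl in place of methoxy on an aromatic carbon, ortho to a large group.

Among the measured compounds shown here, no measured step makes this exact exchange, so the evidence is indirect. Putting 2-methoxyphenyl in place of 4-methoxyphenyl gave a 1.0-fold lower number from compound 1 to compound 2 (0.02 log units; within the scatter). Putting fluoro in place of methoxy on an aromatic carbon gave a 1.1-fold lower number from compound 1 to compound 3 (0.03 log units; within the scatter). Putting 4-fluorophenyl in place of 2-methoxyphenyl gave a 1.0-fold lower number from compound 2 to compound 3 (0.02 log units; within the scatter). For the measured compounds named here, all three changes were made on the same aromatic ring, and all three stayed within the scatter, with no measured compound going against this. No step beyond the scatter is therefore expected in this assay, in either direction.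

The estimated step is no change at the digits printed from compound 2 to compound 4 (within the scatter). Compound 4 is expected at about 2.8 ug/mL, with an estimated range of 1.5 ug/mL to 5 ug/mL.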

Compound 4, concentration for half-maximal effect: 1.6 ug/mL
Estimate against measurement, compound 4: 1.8-fold (0.24 log units) above; low and high end bracket the measured number.
By their numbers in this assay, from the lowest: compounds 4, 3, 2 and 1 (each within the scatter of the next).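

In this assay, methyl in place of methoxy on an aromatic carbon, ortho to a large group, gives a 1.8-fold lower number from compound 2 to compound 4 (0.24 log units; within the scatter) and so shows that this position can lose the oxygen of methoxy, along with its hydrogen-bond acceptor, without a step beyond the usual scatter. The comparisons with the other two compounds point the same way: 2-methylphenyl in place of 4-fluorophenyl gives a 1.7-fold lower number from compound 3 to compound 4 (0.23 log units; within the scatter) and 2-methylphenyl in place of 4-methoxyphenyl gives a 1.8-fold lower number from compound 1 to compound 4 (0.26 log units; within the scatter), so no change on this ring among these four compounds has yet moved the read-out beyond the scatter. No measurement here offers any explanation for these numbers.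

From the compounds shown here alone, the ring in these compounds carries only methoxy, fluoro or methyl, so what an amine, a carboxylic acid or a longer chain would do on it remains open. Going by these compounds, all four compounds also share the same core and are compared on a single read-out, so it remains open whether a change elsewhere on the core would produce a step beyond the scatter.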